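Side-chain variation at the ester-bearing carbon, toward compound 4

The compounds below may be only part of what the source reports. "The series", "measured", "known", "first", "only" and "open" are said of these compounds alone.

Measured so far:
compound 1, `C[C@H](NC(=O)CN(c1nc(Cl)nc2[nH]cnc12)C1CC1)C(=O)OCc1ccccc1`, 44.2%
compound 2, `O=C(CN(c1nc(Cl)nc2[nH]cnc12)C1CC1)NCC(=O)OCc1ccccc1`, 27.2%
compound 3, `NCCCC[C@H](NC(=O)CN(c1nc(Cl)nc2[nH]cnc12)C1CC1)C(=O)OCc1ccccc1`, 35.3%

In a functional assay on the whole organism (Tail, strain ICR) with Mus musculus as the target, in the tail flick test, with a stated time of 90 min, at a dose of 25 umol/kg by the oral route (a higher number here means a stronger effect of the compound at the dose given, a lower number a weaker effect), compound 1 gives 44.2%, compound 2 gives 27.2% and compound 3 gives 35.3%. Compound 3 stands second highest of the three numbers; its gaps to compound 2 and to compound 1 both lie within the scatter, so no order among them is claimed. Compound 4, `NC(=O)C[C@H](NC(=O)CN(c1nc(Cl)nc2[nH]cnc12)C1CC1)C(=O)OCc1ccccc1`, differs from compound 3 by carbamoyl in place of 3-aminopropyl on a saturated chain carbon, two bonds along the chain from an amide-type nitrogen and a carbonyl carbon. The two earlier steps at this same position were small: a number 8.9 percentage points lower from compound 1 to compound 3 (within the scatter) and a number 8.1 percentage points higher from compound 2 to compound 3 (within the scatter). Only a number 17 percentage points lower from compound 1 to compound 2 (beyond the scatter) reached beyond the scatter. A change at this position is therefore expected to stay within the scatter, a number 2.3 percentage points lower from compound 3 to compound 4 (within the scatter). Compound 4 is estimated at 33%, between 18% and 48%.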

Compound 4, a percentage reported as activity, at one dose (the size of the read-out at that dose, not a potency): 32.3%
Compound 4: middle estimate off by 0.7 percentage points, on the high side; measured number inside the range.
By their numbers in this assay, from the lowest: compounds 2, 4, 3 and 1 (each within the scatter of the next, the first and the last beyond it).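

In this assay, carbamoyl in place of 3-aminopropyl leaves the read-out within the scatter (a number 3 percentage points lower from compound 3 to compound 4 (within the scatter)), so a side chain ending in carbamoyl and one ending in an amine are not told apart at this place. Carbamoylmethyl in place of hydrogen also stays within the scatter (a number 5.1 percentage points higher from compound 2 to compound 4 (within the scatter)), while compound 1 now stands beyond the scatter from a second compound (a number 11.9 percentage points lower from compound 1 to compound 4 (beyond the scatter)), though still not from compound 3. No measurement shown here accounts for these steps.

Open, going by these compounds, is whether a carboxylic acid in place of carbamoyl, or a longer chain ending in carbamoyl, would move the number beyond the scatter from compound 4.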